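Swapping the Ester for Trifluoromethyl on the Aryl Urea

A few compounds are considered here, and "the series" means these few. Any claim that something is new, unique, unknown or untested is made for them only; others in the source may bear on it.

Compound 1 `CCOC(=O)c1ccc(NC(=O)N2CC2C#N)cc1` is measured in a functional assay on WiDr cells (Homo sapiens) for inhibition (a higher number here means a weaker inhibitor, a lower number a stronger inhibitor), and gives 4200 nM, the highest of the two numbers shown. Its closest neighbour, compound 2 `N#CC1CN1C(=O)Nc1cccc2ccccc12`, gives 2500 nM in this assay, a gap within the scatter. Compound 3 `N#CC1CN1C(=O)Nc1ccc(C(F)(F)F)cc1` carries trifluoromethyl in place of ethoxycarbonyl on an aromatic carbon. For the measured compounds named here, no measured pair isolates this change, so the direction cannot be read from existing data. The step from compound 1 to compound 3 is expected to be small, a 1.3-fold lower number from compound 1 to compound 3 (0.12 log units; within the scatter), likely no larger than the scatter. Compound 3 is therefore estimated at 3200 nM, with a range from 1000 nM to 10000 nM.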

Compound 3, half-maximal inhibitory concentration: 5800 nM
Beside the measured number, compound 3's estimate is 1.8-fold (0.26 log units) below it; the measured number falls inside the stated range.
By their numbers in this assay, from the lowest: compounds 2, 1 and 3 (each within the scatter of the next, the first and the last beyond it).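

For the compounds shown here, replacing ethoxycarbonyl with trifluoromethyl on this aromatic carbon gives a 1.4-fold higher number from compound 1 to compound 3 (0.14 log units; within the scatter) in this assay and provides the first direct reading at this position. Ethoxycarbonyl counts 2 hydrogen-bond acceptors and trifluoromethyl 0, yet this pair cannot be told apart in this assay. No supporting measurement offers an explanation for this result.

Going by these compounds, whether an amine or a carboxylic acid at this position would move the number beyond the scatter remains open. On these data alone, it is also open whether other changes to the shared core would do so.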